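This account rests on a few compounds, and the source may have more. Where it says the series, first, only, none or still open, it means among the compounds named here.

Working notes on the series. In a functional assay on KB cells (Homo sapiens) for inhibition, read by sulforhodamine B assay, with a stated time of 72 h (on this read-out lower numbers stand for stronger inhibition of growth and higher numbers for weaker inhibition of growth), compound 1 `CN1CCN(C(=O)/C=C/c2ccncc2-c2ccc3ccccc3c2)CC1` gives only a limit, > 10000 nM. Compound 2 `CCOC(=O)/C=C/c1ccncc1-c1ccc2ccccc2c1` also gives only a limit, > 10000 nM. Compound 3 `O=C(O)/C=C/c1ccncc1-c1ccc2ccccc2c1` likewise stands at a limit, > 10000 nM, so it offers no number to build on, and the other two values offer none either.

Compound 4 `COC1CN(C(=O)/C=C/c2ccncc2-c2ccc3ccccc3c2)C1` carries 3-methoxyazetidin-1-yl in place of hydroxy on a carbonyl carbon.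

For the measured compounds named here, three measured steps bear on this change, since all of them alter the same carbonyl end: a step that the two limits leave unreadable from compound 1 to compound 3, a step that the two limits leave unreadable from compound 1 to compound 2 and a step that the two limits leave unreadable from compound 2 to compound 3. None has a readable size. The whole picture so far is the limit of > 10000 nM in this assay, at which 3 of the 3 values shown sit.

Going by the values given here, on the strength of a step that the two limits leave unreadable from compound 1 to compound 3, no step of readable size and no direction can be expected in this assay, and a further limit is the likeliest outcome. The expected change is a step that the limit leaves unreadable from compound 3 to compound 4. For compound 4 the estimated value is 15000 nM, with an expected range of 5000 nM to 40000 nM.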

Compound 4, concentration for 50% growth inhibition: > 10000 nM
Compound 4: no number, only a limit; the forecaster's own chance of this, stated with the estimate: 85%; the middle value is on the limit's open side.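

In this assay, for the compounds shown here, compound 4 gives only a limit, > 10000 nM, so no step among compound 1, compound 2, compound 3 and compound 4 can be read. The compounds shown leave open whether any change at the carbonyl end alters growth inhibition, as the whole picture remains: the limit of > 10000 nM in this assay, at which 4 of the 4 values shown sit.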